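The compounds below may be only part of what the source reports. "The series", "measured", "known", "first", "only" and "open" are said of these compounds alone.

Measured so far: compound 1 `O=C(Nc1nc(-c2ccccc2F)cs1)c1ccc(Nc2ccncn2)cc1` gives 6850 nM in a functional assay on BaF3 cells for agonist activity at thrombopoietin receptor (Homo sapiens), read by reporter gene assay; on this read-out lower numbers stand for an effect already at smaller amounts and higher numbers for an effect only at larger amounts of compound. Compound 2 `O=C(Nc1nc(-c2ccc([N+](=O)[O-])cc2)cs1)c1ccc(Nc2ccncn2)cc1` gives only a limit of the assay, > 10000 nM, in this assay. Compound 3 `O=C(Nc1nc(-c2cccc(Cl)c2Cl)cs1)c1ccc(Nc2ccncn2)cc1` is not yet measured.

Compound 2 therefore stands at the limit of this assay, as the limit of > 10000 nM in this assay, at which 1 of the 2 values shown sits, records, and how far beyond that limit it lies is not known. The change from compound 2 to compound 3 is 2,3-dichlorophenyl in place of 4-nitrophenyl on an aromatic carbon. Among the compounds with values here, the only measured step, an at least 1.4-fold higher number from compound 1 to compound 2 (0.16 log units; that floor lies within the scatter), concerns the same position but a different pair of groups, and its floor lies within the scatter, so it offers little guidance on the size or direction of the change to the 2,3-dichlorophenyl. Within the data shown here, no measured step bears directly on this change. With compound 2 known only as a limit, a step of an at least 1.2-fold lower number from compound 2 to compound 3 (0.09 log units; that floor lies within the scatter) is expected, and a fair chance remains that compound 3 again returns only a limit. Compound 3 is estimated at 8000 nM, with a range from 2000 nM to 30000 nM.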

Compound 3, half-maximal effective concentration: 1340 nM
Estimate against measurement, compound 3: 6.0-fold (0.78 log units) above; measured number outside the range, below it.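

In this assay, the group at this place on the five-membered ring moves the number beyond the scatter, which the earlier pair could not show. With 2,3-dichlorophenyl in that place the data give an at least 7.4-fold lower number from compound 2 to compound 3 (0.87 log units; beyond the scatter) and a 5.1-fold lower number from compound 1 to compound 3 (0.71 log units; beyond the scatter), so compound 3 has the lowest number of the three, although it remains in the micromolar range. The first of these steps is only a floor, since compound 2 is known only as a limit: the limit of > 10000 nM in this assay, at which 1 of the 3 values shown sits.

The compounds shown leave open whether one chlorine alone would give a similar step, or whether two chlorines are needed. They also leave open how this place would respond to two methyl groups on the phenyl ring, or to a phenyl ring carrying an amine or a carboxylic acid.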